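The source may hold more compounds than are shown below. What is called first, only, known or untested is meant among the compounds shown, and "the series" means these compounds.

Working notes on the series.

Of the compounds shown here, two of the shared core have been measured in a functional assay on isolated protein for inhibition of Glucose-dependent insulinotropic receptor (Homo sapiens), read by HTRF and cAMP accumulation; a lower number here means that less compound is needed, a higher number that more compound is needed for the effect. Compound 1 `Cc1nc(S(C)(=O)=O)ccc1Oc1ncnc(OC2CCN(C(=O)O[C@@H](C)CF)CC2)c1F` gives 186 nM. Compound 2 `Cc1nc(S(C)(=O)=O)ccc1Oc1ncnc(OC2CCN(C(=O)SC(C)C)CC2)c1F` gives 6.8 nM and stands lowest of the two numbers, the nearest being compound 1. Among the compounds with values here, the one measured step, a 27-fold lower number from compound 1 to compound 2 (1.44 log units; beyond the scatter), exchanges a group of 4 heavy atoms for a group of 5 heavy atoms on the carbonyl carbon.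

Compound 3 `Cc1nc(S(C)(=O)=O)ccc1Oc1ncnc(OC2CCN(C(=O)C3(F)CCC3)CC2)c1F` is not yet measured. It differs from compound 2 at the same carbonyl carbon: a group of 5 heavy atoms (4 carbon, 1 fluorine; one four-membered non-aromatic ring of carbon only) in place of a group of 4 heavy atoms (3 carbon, 1 sulfur; no ring), on a carbonyl carbon

Within the data shown here, only the step from compound 1 to compound 2 bears on this, and it was large, showing that the group on the carbonyl carbon moves the number well beyond the scatter. The entering group in compound 3 is neither of the two seen so far, so direction is uncertain. Compound 3 is expected to sit between the two measured compounds, a step of a 4.4-fold higher number from compound 2 to compound 3 (0.64 log units; beyond the scatter) upward. For compound 3 the estimate is 30 nM, expected within 6 nM to 150 nM.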

Compound 3, half-maximal effective concentration: 24.7 nM
The estimate for compound 3 lay 1.2-fold (0.08 log units) above the measured number, within the range that was stated.
By their numbers in this assay, from the lowest: compound 2; then compound 3; then compound 1.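

In this assay, the third group on this carbonyl carbon shows that the position tolerates a ring: a 3.6-fold higher number from compound 2 to compound 3 (0.56 log units; beyond the scatter), a modest rise that leaves the fluorinated four-membered carbon ring short of isopropylsulfanyl. The same group also gives a 7.5-fold lower number from compound 1 to compound 3 (0.88 log units; beyond the scatter), so a carbon-linked group with a ring can improve on the fluorinated oxygen-linked chain of compound 1, though not enough to match the sulfur-linked group of compound 2. No measurement at hand bears on why the three groups fall in this order.

Each step changes the linking atom and the rest of the group together, so the contribution of each remains unseparated. Open too, from the compounds shown here alone, is how a cyclobutyl ring without fluorine, or an amine on the carbonyl carbon, would compare with isopropylsulfanyl.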